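The compounds below may be only part of what the source reports. "The series", "measured", "known", "first", "only" and "open" are said of these compounds alone.

In a functional assay on BXPC-3 cells (Homo sapiens) for antiproliferative activity, read by MTT assay, with a stated time of 24 h (on this read-out higher numbers stand for weaker inhibition and lower numbers for stronger inhibition), compound 1 `CCn1c(C(=O)NCCN)ccc1C(CC)(CC)c1ccc(OCS(=O)(=O)c2ccccc2)c(C)c1` gives 6430 nM, compound 2 `CCN(CC)CCNC(=O)c1ccc(C(CC)(CC)c2ccc(OCS(=O)(=O)c3ccccc3)c(C)c2)n1CC` gives 6270 nM, and compound 3 `CCn1c(C(=O)NCCO)ccc1C(CC)(CC)c1ccc(OCS(=O)(=O)c2ccccc2)c(C)c1` gives 19900 nM, the highest of the three numbers. Compound 4 `CCn1c(C(=O)NC(C)(C)CO)ccc1C(CC)(CC)c1ccc(OCS(=O)(=O)c2ccccc2)c(C)c1` carries 1-(hydroxymethyl)-1-methylethyl in place of 2-hydroxyethyl on an amide-type nitrogen. The measured steps concern a different swap. Hydroxy in place of amino gave a 3.1-fold higher number from compound 1 to compound 3 (0.49 log units; beyond the scatter), and hydroxy in place of diethylamino gave a 3.2-fold higher number from compound 2 to compound 3 (0.50 log units; beyond the scatter), both modest, while diethylamino in place of amino gave a 1.0-fold lower number from compound 1 to compound 2 (0.01 log units; within the scatter), within the scatter. None of these tests the present change, and compound 4 keeps the hydroxy of compound 3. No step beyond the scatter is therefore expected in this assay, and the estimated move is a 1.1-fold lower number from compound 3 to compound 4 (0.04 log units; within the scatter). Compound 4 is estimated at 18000 nM, with an expected range of 8000 nM to 38000 nM.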

Compound 4, half-maximal inhibitory concentration: 18300 nM
For compound 4 the middle estimate is 1.0-fold (0.01 log units) below the measured one; measured number inside the range.
By their numbers in this assay, from the lowest: compounds 2 and 1 (each within the scatter of the next); then compounds 4 and 3 (each within the scatter of the next).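

In this assay, 1-(hydroxymethyl)-1-methylethyl on the amide-type nitrogen is tolerated as well as 2-hydroxyethyl, with a 1.1-fold lower number from compound 3 to compound 4 (0.04 log units; within the scatter) as the step. The separation of the hydroxy compounds from the amines also extends to this branched group, with a 2.8-fold higher number from compound 1 to compound 4 (0.45 log units; beyond the scatter) and a 2.9-fold higher number from compound 2 to compound 4 (0.47 log units; beyond the scatter) as its modest steps. No measurement shown here accounts for these steps.

Still open, going by these compounds, is whether a primary amine on the same branched carbon framework would match compound 1, and how a carboxylic acid or a longer hydroxyalkyl chain would fare at this nitrogen.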